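The source may hold more compounds than are shown below. What is called first, only, known or untested is meant among the compounds shown, and "the series" means these compounds.

- Compound 1 `N#CC1(NC(=O)[C@@H]2C[C@@H](S(=O)(=O)c3ccccc3)C[C@H]2C(=O)N2CCCCC2)CC1`: 5 nM
- Compound 2 `N#CC1(NC(=O)[C@@H]2C[C@@H](S(=O)(=O)c3ccccc3)C[C@H]2C(=O)N2CCNCC2)CC1`: 1340 nM

In a functional assay on A20 cells (Mus musculus) for inhibition, with stated times of 1 h, 16 h and 24 h (a lower number here means a stronger inhibitor, a higher number a weaker inhibitor), compound 2 has the higher of the two numbers at 1340 nM, which makes it the weaker inhibitor. Compound 3 `N#CC1(NC(=O)[C@@H]2C[C@@H](S(=O)(=O)c3ccccc3)C[C@H]2C(=O)N2CCC2)CC1` keeps the shared core but carries azetidin-1-yl in place of piperazin-1-yl on a carbonyl carbon. Within the data shown here, the only measured step at this place, a 270-fold higher number from compound 1 to compound 2 (2.43 log units; beyond the scatter), came with piperazin-1-yl replacing piperidin-1-yl and was large. On these data alone, removing piperazin-1-yl is therefore expected to give a large step towards a lower number in this assay, although azetidin-1-yl itself is untested. The expected change is a 45-fold lower number from compound 2 to compound 3 (1.65 log units; beyond the scatter). For compound 3 the estimated value is 30 nM, with an expected range of 6 nM to 150 nM.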

Compound 3, half-maximal inhibitory concentration: 44 nM
Compound 3: the middle estimate sits 1.5-fold (0.17 log units) below what was measured, and the stated range covers the measured number.
By their numbers in this assay, from the lowest: compound 1; then compound 3; then compound 2.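

In this assay, among these compounds, the azetidin-1-yl group gives a 30-fold lower number from compound 2 to compound 3 (1.48 log units; beyond the scatter), so replacing the piperidin-1-yl of compound 1 with piperazin-1-yl is not the only way to change this position, and a four-membered ring lacking the piperazine donor and acceptor keeps much of the activity. Even so, azetidin-1-yl does not fully match piperidin-1-yl, with an 8.8-fold higher number from compound 1 to compound 3 (0.94 log units; beyond the scatter). Nothing measured here explains why these rings differ. It remains open where pyrrolidin-1-yl or morpholin-4-yl on this carbonyl carbon would fall among these three compounds.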